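Moving the fluoro group on compound 2

The source may report more compounds than this note shows. Statements on the series, on what has been measured and on what is new or still open speak of the compounds shown alone.

Compound 2 `COc1cc(NC(C)CCCNC(=O)NNC(=O)Nc2ccc(F)cc2)c2ncccc2c1` gives only a limit in a functional assay on SW-620 cells (Homo sapiens) for inhibition, read by MTT assay, with a stated time of 72 h (on this read-out higher numbers stand for weaker inhibition and lower numbers for stronger inhibition), not a number: > 100000 nM. Compound 4 `COc1cc(NC(C)CCCNC(=O)NNC(=O)Nc2cccc(F)c2)c2ncccc2c1` has the same atoms joined differently, with 3-fluorophenyl in place of 4-fluorophenyl on an amide-type nitrogen. For the measured compounds named here, no measured step makes this exact change. Compound 3 `COc1cc(NC(C)CCCNC(=O)NNC(=O)Nc2ccc(Br)cc2)c2ncccc2c1`, with bromo in place of fluoro on an aromatic carbon, gives 17000 nM. That swap is an at least 5.8-fold lower number from compound 2 to compound 3 (0.76 log units; beyond the scatter), so this end of the molecule can matter. Compound 1 `COc1cc(NC(C)CCCNC(=O)Nc2cccc(F)c2)c2ncccc2c1`, which also carries 3-fluorophenyl, gives 27000 nM, so a modest fall is expected for compound 4. Its other steps are an at least 3.7-fold higher number from compound 1 to compound 2 (0.56 log units; beyond the scatter) and a 1.6-fold lower number from compound 1 to compound 3 (0.20 log units; within the scatter). The expected change is an at least 2.5-fold lower number from compound 2 to compound 4 (0.39 log units; beyond the scatter). Compound 4 is estimated at 40000 nM, with an expected range of 12000 nM to 100000 nM.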

Compound 4, half-maximal inhibitory concentration: 9500 nM
For compound 4 the middle estimate is 4.2-fold (0.62 log units) above the measured one; measured number outside the range, below it.
By their numbers in this assay, from the lowest: compounds 4, 3 and 1 (each within the scatter of the next, the first and the last beyond it). At a limit, above all of these: compound 2.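

In this assay, merely moving the fluorine, with 3-fluorophenyl in place of 4-fluorophenyl, gives an at least 10-fold lower number from compound 2 to compound 4 (1.02 log units; beyond the scatter), so its position on this ring matters as well as the choice of halogen. Compound 2 gives only a limit, so this step has no exact size: the limit of > 100000 nM in this assay, at which 1 of the 4 values shown sits. The 3-fluorophenyl group also gains from the added carbamoylamino link, with a 2.8-fold lower number from compound 1 to compound 4 (0.45 log units; beyond the scatter), while the change of aryl group gives a 1.8-fold lower number from compound 3 to compound 4 (0.25 log units; within the scatter). On these data alone, whether 3-bromophenyl or 3-methoxyphenyl on the same nitrogen would match 3-fluorophenyl remains open.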